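This account rests on a few compounds, and the source may have more. Where it says the series, first, only, none or still open, it means among the compounds named here.

Measured compounds:
Compound 1 `COc1ccc(CNc2nc(SC)nc3ncccc23)cc1`. In an ADME assay on BEAS-2B cells (Homo sapiens) for cytotoxicity, read by MTT assay, with a stated time of 72 h (on this read-out lower numbers stand for stronger inhibition of growth and higher numbers for weaker inhibition of growth), compound 1 gives > 100000 nM, which is a limit of the assay rather than a number.
Compound 2 `CCCCCSc1nc(NCc2ccc([Se]C)cc2)c2ccccc2n1`. In this assay compound 2 gives > 100000 nM, again a limit of the assay and not a number.

Compound 2 therefore stands at the edge of what this assay can report: both values shown sit at the limit of > 100000 nM in this assay, at which 2 of the 2 values shown sit, so neither compound inhibited growth of these cells within the tested range, and no ordering between them can be read from the figures.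

Compound 3 `CSc1nc(NCc2ccc([Se]C)cc2)c2ccccc2n1` is the next step from compound 2. The change is hydrogen in place of butyl on a saturated chain carbon bound to a sulfur; in plain words, hydrogen in place of butyl on a saturated chain carbon bound to a sulfur, so the pentylsulfanyl group becomes a methylsulfanyl group. For the measured compounds named here, no measured pair shows what such a shortening does here. Compound 1, which also carries a methylsulfanyl group on a different core, gives only a limit, and compound 2 with the longer chain gives only a limit, so a step that the limit leaves unreadable from compound 2 to compound 3 is expected, that is none beyond the scatter. Compound 3 is thus expected to show about 150000 nM, with a range from 50000 nM to 500000 nM, and most likely the assay will again report only a limit.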

Compound 3, concentration for total growth inhibition: > 100000 nM
Compound 3 was reported as a limit; the forecaster's own chance of this, stated with the estimate: 85%; the middle value is on the limit's open side.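

In this assay compound 3 gives > 100000 nM, again a limit of the assay and not a number. Compound 2 also gives only a limit, so no step from compound 2 to compound 3 can be read: the limit of > 100000 nM in this assay, at which 3 of the 3 values shown sit.

The compounds shown leave open whether pentylsulfanyl and methylsulfanyl differ at all in their effect on the growth of these cells.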